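Fluoro on the benzamide of compound 2: expected outcome

A few compounds are considered here, and "the series" means these few. Any claim that something is new, unique, unknown or untested is made for them only; others in the source may bear on it.

Two amides of the shared core have numbers in an assay on HEK293 cells for inhibition of Indoleamine 2,3-dioxygenase 1 (Homo sapiens), tested at 10 uM; a lower number here means less inhibition, a higher number more inhibition at the concentration tested (going by the name of the read-out). Compound 1 `CC(C)C(=O)N1CCc2cc(CNC(=O)c3ccc(Cl)cc3)ccc21` gives 92%. Compound 2 `CCC(=O)N1CCc2cc(CNC(=O)c3ccccc3)ccc21` gives 87%, which stands as the lowest of the two numbers shown, the gap to compound 1 lying within the scatter, so no order between the two is claimed. Going by the values given here, no step between measured compounds that differ in one place is available, and nothing measured isolates the change considered here.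

Compound 3 `CCC(=O)N1CCc2cc(CNC(=O)c3cccc(F)c3)ccc21` differs from compound 2 by fluoro in place of hydrogen on an aromatic carbon, read one bond further out as phenyl to 3-fluorophenyl. With both measured compounds high in this assay and within the scatter of each other, the expected step is small, a number 1 percentage points higher from compound 2 to compound 3 (within the scatter), with no direction beyond the scatter. Compound 3 is therefore expected to give 88% in this assay, estimated to fall between 78% and 95%.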

Compound 3, a percentage reported as inhibition, at one concentration (the size of the read-out at that concentration, not a potency): 82%
Compound 3: the middle estimate sits 6 percentage points above what was measured; measured number inside the range.
By their numbers in this assay, from the lowest: compounds 3, 2 and 1 (each within the scatter of the next).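

With fluoro in place of hydrogen on an aromatic carbon, meta to a large group, the series gains its first reading of a change in one place: in this assay the step is a number 5 percentage points lower from compound 2 to compound 3 (within the scatter) and stays inside the usual variation between repeats. The phenyl to 3-fluorophenyl change therefore gives no step beyond the scatter at this position, and compound 3 at 82% remains high at the single concentration tested. Nothing available bears on the reason for this result.

Open, as far as these compounds go, is whether a methoxy group, an amine or a carboxylic acid at the same place on the ring would give a step beyond the scatter. Also open, from the compounds shown here alone, is whether a potency read-out would separate compound 2 and compound 3, which this single-concentration measurement does not.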